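The compounds below may be only part of what the source reports. "The series", "measured", "known", "first", "only" and "open" are said of these compounds alone.

Measured so far:
Compound 1, `CS(=O)(=O)Nc1ccc2c(c1)S(=O)(=O)N=C(C1=C(O)C3CCCC3N(Cc3ccc(F)cn3)C1=O)N2` — in an ADME assay on Huh-7 cells (Homo sapiens) for cytotoxicity, with a stated time of 72 h (a lower number here means that less compound is tolerated, a higher number that more compound is tolerated), compound 1 gives > 33000 nM, which is a limit of the assay and not a number.
Compound 2, `CS(=O)(=O)Nc1ccc2c(c1)S(=O)(=O)N=C(C1=C(O)[C@H]3CCC[C@H]3N(Cc3ccc(F)c(F)c3)C1=O)N2` — in this assay compound 2 gives > 1000 nM, also a limit.
Compound 3, `CC(C)CCN1C(=O)C(C2=NS(=O)(=O)c3cc(NS(C)(=O)=O)ccc3N2)=C(O)C2CCCC21` — in this assay compound 3 gives > 1000 nM, again a limit.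

Compound 3 thus stands at a limit only, and the two further values shown are limits as well. For the measured compounds named here, the single step between measured compounds that differ in one place, a step that the two limits leave unreadable from compound 1 to compound 3, runs from one limit to another and its size is not readable; because of the limit of > 1000 nM in this assay, at which 2 of the 3 values shown sit, and the limit of > 33000 nM in this assay, at which 1 of the 3 values shown sits, no step can be sized at all.

Compound 4, `CC(C)CCN1C(=O)C(C2=NS(=O)(=O)c3cc(NS(C)(=O)=O)ccc3N2)=C(O)[C@H]2CCC[C@H]21`, keeps every atom and bond of compound 3: the two compounds have the same atoms and bonds; at least one stereo element is drawn with a configuration in one of them and without one in the other: 2 of 2 stereo elements differ; a stereocentre at a saturated ring carbon is drawn without a configuration in compound 3 and S in compound 4; a stereocentre at a saturated ring carbon is drawn without a configuration in compound 3 and R in compound 4. Going by the values given here, no measured step concerns a change of this kind, and the one step that exists is unreadable. No step beyond the usual scatter is therefore expected in this assay, in either direction. For compound 4 the estimate is 20000 nM, with a range from 3000 nM to 60000 nM. The step so expected is a step that the limit leaves unreadable from compound 3 to compound 4, most likely reported again only as a limit.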

Compound 4, half-maximal cytotoxic concentration: > 1000 nM
Compound 4: no number, only a limit; the forecaster's own chance of this, stated with the estimate: 80%; the middle value lies beyond the limit too.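

In this assay compound 4 gives > 1000 nM, a limit and not a number. The steps to compound 4 from compound 2 and from compound 3 cannot be read. The compounds shown leave open whether the drawn configuration of compound 4, or isobutyl in place of 3,4-difluorophenyl, changes the half-maximal cytotoxic concentration at all.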